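Swapping the aryl partner on the pyridyl-bearing alkene

The source may hold more compounds than are shown below. What is called first, only, known or untested is meant among the compounds shown, and "the series" means these compounds.

Compound 3 `Cc1ccsc1/C(=C/CCCCC(=O)O)c1cccnc1` gives the lowest number of the three measured in an assay (Equus caballus) for inhibition of Thromboxane-A synthase (Homo sapiens), using microsomes (a higher number here means a weaker inhibitor, a lower number a stronger inhibitor), at 29 nM. Compound 1 `CSC(CCC/C=C(\c1ccccc1)c1cccnc1)C(=O)O` sits within the scatter of it, with 30 nM in this assay. Among the measured compounds shown here, compound 2 `O=C(O)CCCC/C=C(\c1cccnc1)c1cccc(Br)c1` is the outlier of the set, with 180 nM in this assay, and the one step recorded in this direction, a 6.2-fold lower number from compound 2 to compound 3 (0.79 log units; beyond the scatter), is the only change that separates a halogen-bearing phenyl from the thiophene partner.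

Compound 4 `O=C(O)CCCC/C=C(\c1cccnc1)c1cccc(F)c1` is reached from compound 3 by 3-fluorophenyl in place of 3-methylthiophen-2-yl on a double-bonded chain carbon bound to an aromatic carbon and a double-bonded chain carbon. This reverses the kind of change seen in the step from compound 2 to compound 3, except that the halogen is fluorine rather than bromine. From the compounds shown here alone, the data hold nothing on a fluorophenyl partner, so the size of the fluorine-for-bromine difference is unknown. The step that bears on it is a 6.2-fold lower number from compound 2 to compound 3 (0.79 log units; beyond the scatter), a modest step beyond the scatter, and a move back to a halophenyl is therefore expected to raise the number, probably by less than that full amount given the smaller halogen.

For compound 4 the expected step in this assay is a 3.8-fold higher number from compound 3 to compound 4 (0.58 log units; beyond the scatter). Compound 4 is estimated at 110 nM in this assay, within 40 nM to 350 nM.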

Compound 4, half-maximal inhibitory concentration: 55 nM
Compound 4: the middle estimate sits 2.0-fold (0.30 log units) above what was measured; low and high end bracket the measured number.
By their numbers in this assay, from the lowest: compounds 3, 1 and 4 (each within the scatter of the next); then compound 2.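

In this assay, this position gives a 1.9-fold higher number from compound 3 to compound 4 (0.28 log units; within the scatter), so the 3-fluorophenyl and 3-methylthiophen-2-yl partners cannot be told apart here, and a halogen-bearing phenyl is not tied in itself to the higher number seen for compound 2. Fluoro in place of bromo on an aromatic carbon gives a 3.3-fold lower number from compound 2 to compound 4 (0.51 log units; beyond the scatter), beyond the scatter, which isolates the halogen as a change that matters with the rest of the structure held fixed. The earlier step, a 6.2-fold lower number from compound 2 to compound 3 (0.79 log units; beyond the scatter), can therefore no longer be read as a simple preference for the thiophene partner over a phenyl partner, and nothing available explains the difference between bromo and fluoro at this position.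

From the compounds shown here alone, whether bromo is the exception or part of a trend across substituents remains open, and a chloro or methoxy group on the phenyl partner, or a phenyl partner with no substituent on this same chain, would help settle it. Going by these compounds, the contribution of the methyl group on the thiophene partner is also open, and a thiophene ring without that methyl group would address it directly.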